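From Hydroxy to Ethoxy in Compound 2

A few compounds are considered here, and "the series" means these few. Any claim that something is new, unique, unknown or untested is made for them only; others in the source may bear on it.

In a functional assay on HL-60 cells (Homo sapiens) for cytotoxicity, read by WST assay, with a stated time of 48 h (a lower number here means that less compound is needed, a higher number that more compound is needed for the effect), compound 1 (`COCOc1ccc(C[C@H]2C(=O)OC[C@@H]2Cc2ccccc2)cc1`) gives 71000 nM, while compound 2 (`O=C1OC[C@H](Cc2ccccc2O)[C@H]1Cc1ccc(Cl)c(Cl)c1`) gives 33000 nM, the lower of the two numbers and separated from compound 1 by more than the scatter. Compound 3 (`CCOc1ccccc1C[C@H]1COC(=O)[C@@H]1Cc1ccc(Cl)c(Cl)c1`) turns the hydroxy of compound 2 into ethoxy: ethyl in place of hydrogen on an oxygen on an aromatic ring, with ethyl in place of hydrogen on an oxygen on an aromatic ring. Going by the values given here, no measured pair shows this change. The expected result in this assay is a 1.1-fold lower number from compound 2 to compound 3 (0.04 log units; within the scatter), a step not expected to go beyond the scatter. Compound 3 is expected at 30000 nM, with an estimated range of 11000 nM to 80000 nM.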

Compound 3, half-maximal effective concentration: 15000 nM
Compound 3: middle estimate off by 2.0-fold (0.30 log units), on the high side; the measured number falls inside the stated range.
By their numbers in this assay, from the lowest: compound 3; then compound 2; then compound 1.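

In this assay, going by these compounds alone, ethyl in place of hydrogen on an oxygen on an aromatic ring gives a 2.2-fold lower number from compound 2 to compound 3 (0.34 log units; beyond the scatter), the first step here that isolates a single change. It shows that the hydroxy hydrogen at this place is not needed for the effect in this pair, and that the ethyl group is tolerated there. Nothing measured here accounts for the step. On these data alone, whether methoxy, a longer chain or an amine at this place would give a lower or higher number remains open. So does whether this step would recur on another core.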